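A few compounds are considered here, and "the series" means these few. Any claim that something is new, unique, unknown or untested is made for them only; others in the source may bear on it.

Measured in a functional assay on the whole organism with Rattus norvegicus as the target; a higher number here means that more compound is needed for the effect, a lower number that less compound is needed:
Compound 1 `CC(C)(C)CCc1cc(C(F)(F)F)ccc1CNC(=O)Nc1cccc2[nH]ncc12`: 0.015 umol/kg
Compound 2 `CC(C)(C)COc1nc(C(F)(F)F)ccc1CNC(=O)Nc1cccc2[nH]ncc12`: > 0.1 umol/kg (a limit, not a number)
Compound 3 `CC(C)(F)CCc1cc(C(F)(F)F)ccc1CNC(=O)Nc1cccc2[nH]ncc12`: 0.058 umol/kg

Of the two actual numbers, compound 3 has the higher, at 0.058 umol/kg. Compound 4 `O=C(NCc1ccc(C(F)(F)F)cc1CCc1ccccc1)Nc1cccc2[nH]ncc12` differs from compound 3 as follows: phenyl in place of 1-fluoro-1-methylethyl on a saturated chain carbon, two bonds along the chain from an aromatic carbon. Among the measured compounds shown here, the only measured step on this chain is a 3.9-fold higher number from compound 1 to compound 3 (0.59 log units; beyond the scatter), a modest step. For the measured compounds named here, no measured compound carries the phenyl, so that step gives the likely size of a change here but not its direction. In this assay, on these data alone, the expectation is therefore no step beyond the scatter, with a modest step either way still open. For compound 4 the estimated value is 0.06 umol/kg, with an expected range of 0.015 umol/kg to 0.25 umol/kg. The expected step is a 1.0-fold higher number from compound 3 to compound 4 (0.01 log units; within the scatter).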

Compound 4, dose for half-maximal effect: 0.03 umol/kg
The estimate for compound 4 lay 2.0-fold (0.30 log units) above the measured number, and the stated range covers the measured number.
By their numbers in this assay, from the lowest: compounds 1, 4 and 3 (each within the scatter of the next, the first and the last beyond it). At a limit, above all of these: compound 2.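

At this saturated chain carbon, two bonds along the chain from an aromatic carbon, this assay accepts an aromatic ring: phenyl in place of 1-fluoro-1-methylethyl gives a 1.9-fold lower number from compound 3 to compound 4 (0.29 log units; within the scatter), and phenyl in place of tert-butyl gives a 2.0-fold higher number from compound 1 to compound 4 (0.30 log units; within the scatter). The earlier compounds shown here carried only saturated branched groups here, and compound 4 now lies within the scatter of both compound 1 and compound 3. No measurement at hand gives a cause for these steps.

Still open, on these data alone, is whether a pyridyl in place of the phenyl, or a chlorine or an amine on it, keeps this level. As far as these compounds go, a longer chain carrying the phenyl is equally open.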